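Nitro in place of hydrogen: an unmeasured analogue of compound 1

The source may hold more compounds than are shown below. What is called first, only, known or untested is meant among the compounds shown, and "the series" means these compounds.

Compound 1 `COc1ccc(Oc2ccccc2-c2ccsc2S(=O)(=O)N2CCN(C(=O)Nc3ccc([N+](=O)[O-])cc3)CC2)cc1OC` is tested in a functional assay on HeLa cells (Homo sapiens) for inhibition, read by CCK-8 assay, with a stated time of 48 h; a higher number here means a weaker inhibitor, a lower number a stronger inhibitor. In this assay compound 1 gives > 50000 nM, which is a limit of the assay and not a number. Compound 2 `O=C(NCCNS(=O)(=O)c1cc(-c2ccccc2Oc2ccc(O)c(O)c2)cs1)Nc1cc(C(F)(F)F)cc(C(F)(F)F)c1` gives > 20000 nM in this assay, again a limit rather than a number. Within the data shown here, compound 1 therefore stands only at a limit (the limit of > 50000 nM in this assay, at which 1 of the 2 values shown sits), and the one further value shown is also a limit (the limit of > 20000 nM in this assay, at which 1 of the 2 values shown sits); no step between measured compounds can be drawn from these two values. Compound 3 `COc1ccc(Oc2ccc([N+](=O)[O-])cc2-c2ccsc2S(=O)(=O)N2CCN(C(=O)Nc3ccc([N+](=O)[O-])cc3)CC2)cc1OC` is not yet measured. It differs from compound 1 by nitro in place of hydrogen on an aromatic carbon. With both measured values sitting at limits, the expected step is a number no higher from compound 1 to compound 3 (the limit leaves the size open), that is, none beyond the scatter, and a further limit is the most likely report. Compound 3 is estimated at 50000 nM in this assay, with a range from 15000 nM to 200000 nM.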

Compound 3, half-maximal inhibitory concentration: > 50000 nM
Compound 3: only a limit was reported; the forecaster's own chance of this, stated with the estimate: 75%; the middle value lies on the limit itself.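

In this assay compound 3 gives > 50000 nM, a limit of the assay and not a number. Compound 1 gives > 50000 nM, also a limit, and no step can be read between compound 1 and compound 3. The compounds shown leave open what nitro in place of hydrogen does to the read-out, and whether any compound of this series gives a number.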